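A few compounds are considered here, and "the series" means these few. Any claim that something is new, unique, unknown or untested is made for them only; others in the source may bear on it.

Compound 1 `CCCCCCCCCCCCOc1ccc(C(=O)/C=C/c2c(/C=C/c3ccc(OC)cc3)cc(OC)cc2OC)cc1`: 11.6 ug/mL
Compound 2 `COc1ccc(/C=C/c2cc(OC)cc(OC)c2/C=C/C(=O)c2cccc(Br)c2)cc1`: 13 ug/mL

Both were tested in a functional assay on HepG2 cells (Homo sapiens) for antiproliferative activity, read by MTT assay, with a stated time of 48 h; on this read-out higher numbers stand for weaker inhibition and lower numbers for stronger inhibition. Compound 2 gives the higher of the two numbers, yet compound 1 lies so close that the gap falls within the usual scatter of repeated measurements, so the two cannot be told apart. Compound 3 `COc1ccc(/C=C/c2cc(OC)cc(OC)c2/C=C/C(=O)c2ccccc2C)cc1` differs from compound 2 in one place: 2-methylphenyl in place of 3-bromophenyl on a carbonyl carbon. Among the measured compounds shown here, no measured pair shows this exchange, so nothing here points to a step beyond the scatter in either direction. Compound 3 is therefore estimated at 13 ug/mL, with a likely range from 6 ug/mL to 28 ug/mL. The step expected no change at the digits printed from compound 2 to compound 3 (within the scatter) is essentially none.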

Compound 3, half-maximal inhibitory concentration: 5.3 ug/mL
Compound 3: middle estimate off by 2.5-fold (0.39 log units), on the high side; the measured number lies below the stated range.
By their numbers in this assay, from the lowest: compound 3; then compounds 1 and 2 (each within the scatter of the next).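

In this assay the exchange of 3-bromophenyl for 2-methylphenyl on the carbonyl carbon brings a 2.5-fold lower number from compound 2 to compound 3 (0.39 log units; beyond the scatter) and so shows that this group can move the result beyond the scatter, if only modestly. No measurement shown explains the drop. The exchange alters both the substituent and its numbered place on the ring, and these compounds cannot separate the two. On these data alone, how 2-bromophenyl or 3-methylphenyl would compare stays open, as does the effect of an amine or a carboxylic acid on that ring.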